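Moving the Oxygen: Methoxy Out, Hydroxymethyl In

The source may hold more compounds than are shown below. What is called first, only, known or untested is meant among the compounds shown, and "the series" means these compounds.

Three compounds have been measured in a functional assay on HCT-116 cells (Homo sapiens) for antiproliferative activity, read by sulforhodamine B assay, with a stated time of 72 h; a higher number here means a weaker inhibitor, a lower number a stronger inhibitor:

compound 1, `CNC(=O)C[C@@H]1C[C@@H](c2ccc(F)c(F)c2)[C@H](NC(=O)c2cc(-c3c(Cl)cnn3C)c(Cl)o2)CN1`, gives 1100 nM
compound 2, `COCC[C@@H]1C[C@@H](c2ccc(Cl)c(Cl)c2)[C@H](NC(=O)c2cc(-c3c(Cl)cnn3C)c(Cl)o2)CN1`, gives 470 nM
compound 3, `Cn1ncc(Cl)c1-c1cc(C(=O)N[C@@H]2CN[C@H](CC(O)CO)C[C@H]2c2ccc(F)c(F)c2)oc1Cl`, gives 800 nM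

Compound 2 stands at the low end of these three numbers. Its gap to compound 3 lies within the scatter, so the two cannot be ordered; only its gap to compound 1 is beyond the scatter. Among the measured compounds shown here, the one step among measured compounds that differ in a single place is a 1.4-fold lower number from compound 1 to compound 3 (0.14 log units; within the scatter), a change of the side chain on the shared core that left the number essentially where it was.

Compound 4, `Cn1ncc(Cl)c1-c1cc(C(=O)N[C@@H]2CN[C@H](CCCO)C[C@H]2c2ccc(Cl)c(Cl)c2)oc1Cl`, has not yet been measured in this assay. It differs from compound 2 by hydroxymethyl in place of methoxy on a saturated chain carbon, two bonds along the chain from a saturated ring carbon. For the measured compounds named here, no measured pair shows this exact rearrangement, so the only guidance is the side-chain step from compound 1 to compound 3, which stayed within the scatter. On that basis the step from compound 2 to compound 4 in this assay is expected to be small, a 1.1-fold higher number from compound 2 to compound 4 (0.04 log units; within the scatter), with no direction beyond the scatter. Compound 4 is therefore estimated at 520 nM, in a range from 230 nM to 1200 nM.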

Compound 4, half-maximal inhibitory concentration: 510 nM
Beside the measured number, compound 4's estimate is 1.0-fold (0.01 log units) above it; the measured number falls inside the stated range.
By their numbers in this assay, from the lowest: compounds 2, 4, 3 and 1 (each within the scatter of the next, the first and the last beyond it).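

Exchanging methoxy for hydroxymethyl on a saturated chain carbon, two bonds along the chain from a saturated ring carbon, gives in this assay a 1.1-fold higher number from compound 2 to compound 4 (0.04 log units; within the scatter). Among the compounds shown here, this is the first single-place step read at this position on the core of compound 2, and it shows that 2-methoxyethyl and 3-hydroxypropyl cannot be told apart here, even though the change goes from 0 hydrogen-bond donors in methoxy to 1 hydrogen-bond donor in hydroxymethyl, with the same atoms joined differently. Together with a 1.4-fold lower number from compound 1 to compound 3 (0.14 log units; within the scatter), on the core of compound 1, both side-chain steps now in hand stay within the scatter, and no compound shown goes against this, though no measurement shown here bears on what lies behind it.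

Compounds 1 and 3 differ from compounds 2 and 4 in more than one place, so the two steps can be set side by side only as separate readings, not compared as one series. As far as these compounds go, whether an amine, a carboxylic acid or a longer chain in place of these side chains would also leave the number within the scatter remains open.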